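Dropping One Methoxy: From Compound 1 to Compound 3

The source may report more compounds than this note shows. Statements on the series, on what has been measured and on what is new or still open speak of the compounds shown alone.

Compound 1 `COc1ccc(/C=N/Nc2nc3ccccc3nc2Cc2ccccc2)cc1OC` and compound 2 `COc1ccc(/C(C)=N/Nc2nc3ccccc3nc2Cc2ccccc2)cc1` share the same core and differ only in the ring at the far end and the carbon attached to it. In an assay on isolated protein for inhibition of Amine oxidase [flavin-containing] A (Homo sapiens), read by spectrophotometry (a lower number here means a stronger inhibitor, a higher number a weaker inhibitor), compound 1 gives 56 nM. In this assay compound 2 gives 89 nM. These two numbers sit within the usual scatter of each other, so compound 1 cannot be set apart from compound 2 on these values alone. Compound 2 differs from compound 1 in more than one place. Among the measured compounds shown here, no single-change step between measured compounds is available.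

Compound 3 `COc1ccc(/C=N/Nc2nc3ccccc3nc2Cc2ccccc2)cc1` differs from compound 1 in exactly one place: hydrogen in place of methoxy on an aromatic carbon. For the measured compounds named here, with no measured step of this kind, the expectation leans on compound 2, which also carries a single methoxy on that ring and whose value 89 nM lies within scatter of compound 1. The step of a 1.4-fold higher number from compound 1 to compound 3 (0.15 log units; within the scatter) is therefore expected to be small, leaning toward a higher number but not clearly beyond the scatter. Compound 3 is estimated at 80 nM, with a range from 35 nM to 180 nM.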

Compound 3, half-maximal inhibitory concentration: 63 nM
Estimate against measurement, compound 3: 1.3-fold (0.10 log units) above; the measured number falls inside the stated range.
By their numbers in this assay, from the lowest: compounds 1, 3 and 2 (each within the scatter of the next).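

Among the compounds shown here, the step (a 1.1-fold higher number from compound 1 to compound 3 (0.05 log units; within the scatter)) in this assay is the first comparison here in which only one thing differs, so it isolates this methoxy group from everything else in the molecule. The pair with compound 2 could not do that, since compound 2 differs from compound 1 in more than one place. Going from 3,4-dimethoxyphenyl to 4-methoxyphenyl, with hydrogen taking the place of the methoxy on the aromatic carbon ortho to a methoxy group and meta to a large group, gives two numbers that cannot be told apart, so this methoxy is not needed to keep the number in this range. Nothing available explains this result.

Going by these compounds, only hydrogen and methoxy have been compared at this place, so it remains open whether a hydroxyl group, an amine or a longer chain such as ethoxy would give a number beyond the scatter. The compounds shown also leave open what happens when the remaining methoxy of compound 3 gives way to hydrogen as well.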